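The source may report more compounds than this note shows. Statements on the series, on what has been measured and on what is new or still open speak of the compounds shown alone.

Measured so far:
- compound 1, `Cn1c(=O)c(S(=O)(=O)Cc2ccc(F)cc2)cc2cnc(Nc3ccc4[nH]ccc4c3)nc21`: 30000 nM
- compound 2, `COC(=O)Cn1ccc2cc(Nc3ncc4cc(S(=O)(=O)c5ccc(F)cc5F)c(=O)n(C)c4n3)ccc21`: 5000 nM
- compound 3, `CCn1c(=O)c(S(=O)(=O)c2ccc(F)cc2F)cc2cnc(Nc3ccc4[nH]ccc4c3)nc21`: 750 nM

These three compounds share a core and were tested in a functional assay on K562 cells (Homo sapiens) for inhibition, read by trypan blue exclusion, with a stated time of 72 h; a higher number here means a weaker inhibitor, a lower number a stronger inhibitor. Compound 1 gives the highest number of the three, so it is the weakest inhibitor here; compound 2 sits a long way lower, and compound 3 lower still, both gaps well beyond the scatter. For the measured compounds named here, compound 3 differs from compound 1 in more than one place, so no single step between measured compounds is known. Compound 4, `Cn1c(=O)c(S(=O)(=O)c2ccc(N)cc2F)cc2cnc(Nc3ccc4[nH]ccc4c3)nc21`, is not yet measured. It differs from compound 1 by 4-amino-2-fluorophenyl in place of 4-fluorobenzyl on a sulfonyl sulfur. In this assay the step from compound 1 to compound 4 is expected to be a 10-fold lower number from compound 1 to compound 4 (1.00 log units; beyond the scatter), towards a lower number. Compound 4 is therefore estimated at 3000 nM, with a range from 800 nM to 12000 nM.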

Compound 4, half-maximal inhibitory concentration: 1500 nM
Compound 4: middle estimate off by 2.0-fold (0.30 log units), on the high side; measured number inside the range.
By their numbers in this assay, from the lowest: compounds 3 and 4 (each within the scatter of the next); then compound 2; then compound 1.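

In this assay, for the compounds shown here, 4-amino-2-fluorophenyl in place of 4-fluorobenzyl on a sulfonyl sulfur gives a 20-fold lower number from compound 1 to compound 4 (1.30 log units; beyond the scatter), the first step here that changes only one place. The group on this sulfur therefore has a large effect on the number, even though the entering and leaving groups have the same heavy-atom count. No measurement shown here explains the step. From the compounds shown here alone, the swap changes several features at once, so the share of the amine alone stays open. Also open, going by these compounds, is what a hydroxyl or a methoxy group in its place would give.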